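The source may hold more compounds than are shown below. What is called first, only, known or untested is meant among the compounds shown, and "the series" means these compounds.

Measured so far:
compound 1 `Nc1oc2ccc(Cl)cc2c(=O)c1/C=N/NCCO` — 6600 nM
compound 2 `COC(=O)N/N=C/c1coc2ccccc2c1=O` — 371000 nM
compound 3 `COC(=O)N/N=C/c1c(N)oc2ccccc2c1=O` — 463000 nM

In a functional assay on HL-60 cells (Homo sapiens) for cytotoxicity, read by MTT assay, with a stated time of 48 h (a lower number here means a stronger inhibitor, a higher number a weaker inhibitor), compound 3 gives the highest of the three numbers, meaning the weakest inhibition; its nearest neighbour is compound 2, and the step of a 1.2-fold higher number from compound 2 to compound 3 (0.10 log units; within the scatter) lies within the scatter, so the two cannot be told apart. Compound 1 stands far away from compound 3, with a much lower number.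

Compound 4 `Nc1oc2ccccc2c(=O)c1/C=N/NCCO` is not yet measured. It differs from compound 3 in one place: 2-hydroxyethyl in place of methoxycarbonyl on an amine nitrogen. Going by the values given here, none of the measured steps covers this exchange; the only measured step, a 1.2-fold higher number from compound 2 to compound 3 (0.10 log units; within the scatter), concerns the amino group and says nothing about the group on the amine nitrogen. Among the compounds with values here, the one compound that carries the same (2-hydroxyethyl)amino group is compound 1, and in this assay compound 1 gives 6600 nM, far lower than compound 3. On that comparison alone the expectation is that compound 4 drops sharply, with an estimated step of a 39-fold lower number from compound 3 to compound 4 (1.59 log units; beyond the scatter). The estimate for compound 4 in this assay is therefore 12000 nM, with a range from 3000 nM to 60000 nM.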

Compound 4, half-maximal inhibitory concentration: 48500 nM
Compound 4: middle estimate off by 4.0-fold (0.61 log units), on the low side; measured number inside the range.
By their numbers in this assay, from the lowest: compound 1; then compound 4; then compounds 2 and 3 (each within the scatter of the next).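

Read on its own in this assay, the change from methoxycarbonyl to 2-hydroxyethyl on the amine nitrogen gives a 9.5-fold lower number from compound 3 to compound 4 (0.98 log units; beyond the scatter) and so lies beyond the scatter, showing that the group at this position affects the number, which the single earlier step, concerned only with the amino group, could not show. Compound 4 also isolates a second change: hydrogen in place of chloro on an aromatic carbon gives a 7.3-fold higher number from compound 1 to compound 4 (0.87 log units; beyond the scatter), so the chloro group of compound 1 goes with the lower number. The wide distance between compound 1 and compound 3 therefore breaks into two single changes, each beyond the scatter, and neither one alone covers the whole distance.

These compounds leave open whether a longer chain such as 3-hydroxypropyl, a chain ending in an amine or a carboxylic acid, or a plain ethyl group would move the number further at the amine nitrogen, and whether bromo or methyl would serve in place of chloro on the aromatic carbon. No measurement here says why either change shifts the number.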